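The compounds below may be only part of what the source reports. "The series", "measured", "known", "first", "only" and "open" are said of these compounds alone.

Three compounds share one core, an amide that carries an aminophenyl group and, on the far side, a thiocarbonyl linked through sulfur to a variable amine. Compound 1 `Nc1ccccc1NC(=O)c1ccc(CSC(=S)N2CCN(c3ccccc3)CC2)cc1` bears a phenylpiperazine there, compound 2 `Nc1ccccc1NC(=O)c1ccc(CSC(=S)N2CCc3ccccc32)cc1` a 2,3-dihydro-1H-indol-1-yl group, and compound 3 `CN(C(=S)SCc1ccc(C(=O)Nc2ccccc2N)cc1)c1cccnc1` a methyl(pyridin-3-yl)amino group. In a functional assay on MGC-803 cells (Homo sapiens) for antiproliferative activity, read by CCK-8 assay, with a stated time of 72 h, tested at 2 uM (a lower number here means a weaker effect, a higher number a stronger effect of the compound at the concentration tested), compound 1 gives 42.3%, compound 2 gives 44%, and compound 3 gives 46.1%. Compound 3 thus gives the highest of the three numbers, yet both others lie within the scatter of it: the step of a number 2.1 percentage points higher from compound 2 to compound 3 (within the scatter) is small, and compound 1 sits only a little further off.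

Compound 4 `Nc1ccccc1NC(=O)c1ccc(CSC(=S)N2CCCc3ccccc32)cc1` is the next member. It differs from compound 3 in one place: 1,2,3,4-tetrahydroquinolin-1-yl in place of methyl(pyridin-3-yl)amino on a thiocarbonyl carbon. Among the compounds with values here, the entering 1,2,3,4-tetrahydroquinolin-1-yl group resembles the 2,3-dihydro-1H-indol-1-yl group of compound 2 in being a fused bicyclic amine, so the one measured step that bears on this change is a number 2.1 percentage points higher from compound 2 to compound 3 (within the scatter), and it stayed within the scatter. A change of this kind is therefore expected to move this assay by little, if at all. For compound 4 the expected value is 44%, with a likely range from 33% to 55%, which means an expected step of a number 2.1 percentage points lower from compound 3 to compound 4 (within the scatter) that does not exceed the scatter.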

Compound 4, a percentage reported as inhibition, at one concentration (the size of the read-out at that concentration, not a potency): 38.5%
The estimate for compound 4 lay 5.5 percentage points above the measured number; the measured number falls inside the stated range.
By their numbers in this assay, from the lowest: compounds 4, 1, 2 and 3 (each within the scatter of the next).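

In this assay, 1,2,3,4-tetrahydroquinolin-1-yl in place of methyl(pyridin-3-yl)amino gives a number 7.6 percentage points lower from compound 3 to compound 4 (within the scatter), so on this thiocarbonyl carbon a group with a six-membered aromatic ring holding a hetero atom can give way to a larger fused amine without the read-out leaving the scatter. The second new comparison, the same group in place of 2,3-dihydro-1H-indol-1-yl, gives a number 5.5 percentage points lower from compound 2 to compound 4 (within the scatter), so the two fused amines, which differ in the size of their non-aromatic ring, cannot be told apart here, and the four amines shown form a chain in which each value lies within the scatter of the next. No measured property of these groups is available to account for these numbers.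

On these data alone, whether a much smaller or more different amine on this carbon, such as dimethylamino or morpholine, would move this assay beyond the scatter remains open. Each number also comes from a single concentration, so it shows only how strong or weak the effect of a compound is at that concentration.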